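Swapping the aryl group on compound 2

The source may hold more compounds than are shown below. What is called first, only, known or untested is meant among the compounds shown, and "the series" means these compounds.

compound 1 `CCOC(=O)c1c(-c2cccc(Cl)c2)[nH]c2cc(OC)c(F)cc2c1=O`: 48900 ng.h/mL
compound 2 `CCOC(=O)c1c(-c2cccc(Br)c2)[nH]c2cc(OC)c(F)cc2c1=O`: 29800 ng.h/mL

Among the measured compounds shown here, the only measured step in an ADME assay on the whole organism (plasma, strain CD1) for pharmacokinetics, with Mus musculus as the target, at a dose of 50 mg/kg by the oral route (on this read-out higher numbers stand for higher exposure at the dose given and lower numbers for lower exposure), is a 1.6-fold lower number from compound 1 to compound 2 (0.22 log units; within the scatter). Compound 2 therefore cannot be told apart from the other measured compound on these numbers.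

Compound 3 `CCOC(=O)c1c(-c2cc(F)cc(OC)c2)[nH]c2cc(OC)c(F)cc2c1=O` keeps the shared core and changes one group: 3-fluoro-5-methoxyphenyl in place of 3-bromophenyl on an aromatic carbon. This is 3-fluoro-5-methoxyphenyl in place of 3-bromophenyl, a larger change than bromo in place of chloro. The measured step therefore offers only a loose guide. For the measured compounds named here, no measured compound carries a methoxy group on this aryl ring, so the direction is uncertain and the range must stay wide. Going by the values given here, the one guide available is a 1.6-fold lower number from compound 1 to compound 2 (0.22 log units; within the scatter), so no clear change beyond the scatter is expected. The estimated step is a 1.2-fold lower number from compound 2 to compound 3 (0.09 log units; within the scatter). For compound 3 the expected number is 24000 ng.h/mL, with an estimated range from 8000 ng.h/mL to 70000 ng.h/mL.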

Compound 3, area under the concentration-time curve: 3620 ng.h/mL
Compound 3: middle estimate off by 6.6-fold (0.82 log units), on the high side, outside the stated range (below it).
By their numbers in this assay, from the lowest: compound 3; then compounds 2 and 1 (each within the scatter of the next).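

In this assay, the aryl group on the shared core proved able to shift exposure well beyond the scatter, which the swap of chloro for bromo could not show. Replacing the 3-bromophenyl with 3-fluoro-5-methoxyphenyl gives an 8.2-fold lower number from compound 2 to compound 3 (0.92 log units; beyond the scatter), and replacing the 3-chlorophenyl with the same group gives a 14-fold lower number from compound 1 to compound 3 (1.13 log units; beyond the scatter), so both halogen compounds stand clearly apart from compound 3. No measurement here explains why exposure falls with this change.

The new aryl group differs from the old ones in more than one feature, so the compounds shown cannot separate the part played by the methoxy group from that of the fluoro group. Going by these compounds, how an amine or a carboxylic acid on this aryl ring would affect exposure also remains open.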